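The source may report more compounds than this note shows. Statements on the series, on what has been measured and on what is new or still open speak of the compounds shown alone.

In an ADME assay on MT4 cells (Homo sapiens) for cytotoxicity, read by MTT assay, with a stated time of 96 h (a lower number here means that less compound is tolerated, a higher number that more compound is tolerated), compound 1 `COc1ccc(-c2nc3cc(C(C)=O)ccc3[nH]2)c(OC)c1` gives 50000 nM. Compound 2 `COc1ccc(-c2nc3cc(C(C)=O)ccc3[nH]2)c(OC)c1OC` gives > 100000 nM, a limit and not a number, so it stands only at the limit of > 100000 nM in this assay, at which 1 of the 2 values shown sits. Compound 3 `COc1ccc(-c2nc3cc(/C(C)=N/O)ccc3[nH]2)c(OC)c1OC` replaces the acetyl on an aromatic carbon: a group of 4 heavy atoms (2 carbon, 1 nitrogen, 1 oxygen; no ring) in place of a group of 3 heavy atoms (2 carbon, 1 oxygen; no ring), on an aromatic carbon. For the measured compounds named here, the one measured step, an at least 2.0-fold higher number from compound 1 to compound 2 (0.30 log units; that floor lies within the scatter), is methoxy in place of hydrogen on an aromatic carbon; it leaves the acetyl untouched and gives no size for this change. No step beyond the scatter is expected, and the estimated step is an at least 1.4-fold lower number from compound 2 to compound 3 (0.15 log units; that floor lies within the scatter). For compound 3 the estimate is 70000 nM, with an expected range of 20000 nM to 100000 nM.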

Compound 3, half-maximal cytotoxic concentration: 51000 nM
Compound 3: the middle estimate sits 1.4-fold (0.14 log units) above what was measured, and the stated range covers the measured number.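

In this assay the acetyl position now has a reading of its own: the group of 4 heavy atoms in place of acetyl, which brings a hydrogen-bond donor, gives an at least 1.9-fold lower number from compound 2 to compound 3 (0.29 log units; that floor lies within the scatter) and leaves this change without a step beyond the scatter. That step has only a floor, since compound 2 is held by a limit and not a number: the limit of > 100000 nM in this assay, at which 1 of the 3 values shown sits.

Still open, from the compounds shown here alone, is how an amine, a carboxylic acid or a longer chain on this aromatic carbon would read. Going by these compounds, the full size of the step also remains open.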